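A few compounds are considered here, and "the series" means these few. Any claim that something is new, unique, unknown or untested is made for them only; others in the source may bear on it.

Compound 1, `c1cnc(CN(CCCN2CCNCC2)[C@H]2CCCc3cccnc32)nc1`, was tested in a functional assay on CCRF-CEM cells for antagonist activity at C-X-C chemokine receptor type 4 (Homo sapiens), read by calcium flux, with stated times of 25 min and 90 s (on this read-out lower numbers stand for stronger inhibition and higher numbers for weaker inhibition), where compound 1 gives 4320 nM. Among the compounds with values here, only one other compound has a number here: compound 2, `NC(=O)N1CCN(CCCN(C[C@H]2Cc3ccccc3CN2)[C@H]2CCCc3cccnc32)CC1`, which in this assay gives 959 nM. So compound 1 stands with the highest of the two numbers, and the gap to compound 2 lies beyond the scatter, so compound 2 is the stronger inhibitor of the pair.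

The next compound, compound 3, `c1cnc2c(c1)CN[C@@H](CN(CCCN1CCNCC1)[C@H]1CCCc3cccnc31)C2`, has not yet been measured. It differs from compound 1 in one place: a group of 10 heavy atoms (8 carbon, 2 nitrogen; one six-membered non-aromatic ring with 1 hetero atom, one six-membered aromatic ring with 1 hetero atom) in place of a group of 6 heavy atoms (4 carbon, 2 nitrogen; one six-membered aromatic ring with 2 hetero atoms), on a saturated chain carbon bound to an amine nitrogen The entering group brings a hydrogen-bond donor that the pyrimidin-2-yl group lacks.

Within the data shown here, no measured pair shows this exact exchange, so the size of the step can only be guessed. Compound 2 carries a related two-ring group with a hydrogen-bond donor at the same kind of position and gives 959 nM, a lower number than compound 1, although compound 2 also differs elsewhere. Compound 3 is therefore expected to give about 1100 nM, likely between 350 nM and 3500 nM. This estimate means the step of a 3.9-fold lower number from compound 1 to compound 3 (0.59 log units; beyond the scatter) is expected to go toward a lower number, beyond the scatter.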

Compound 3, half-maximal inhibitory concentration: 171 nM
The estimate for compound 3 lay 6.4-fold (0.81 log units) above the measured number; the whole stated range lies above it.
By their numbers in this assay, from the lowest: compound 3; then compound 2; then compound 1.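

In this assay the exchange of the pyrimidin-2-yl group for the larger two-ring group, on a saturated chain carbon bound to an amine nitrogen, gives a 25-fold lower number from compound 1 to compound 3 (1.40 log units; beyond the scatter) and is a large step beyond the scatter. Within the data shown here, this is the first single exchange that can be read here, and it shows that inhibition depends strongly on what sits at this position, with the rest of the structure unchanged. No measurement given here explains the size of this step.

The entering group differs from the pyrimidin-2-yl group in several ways at once, since it has more heavy atoms, a non-aromatic ring, a hydrogen-bond donor and a defined stereocentre, so this one step cannot show which of these features goes with the lower number. A simple piperidin-2-yl group, with a six-membered non-aromatic ring holding one nitrogen and no second ring, would help to separate these features, and how it would compare in this position remains an open question.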